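Swapping a thiazole for a thiophene on a shared anilide core

The source may report more compounds than this note shows. Statements on the series, on what has been measured and on what is new or still open speak of the compounds shown alone.

Measured so far:
compound 1, `O=C(Nc1ccc(-c2cscn2)cc1)C1CCCN(Cc2ccc(F)c(F)c2)C1`, 1240 nM
compound 2, `O=C(Nc1ccc(-c2cscn2)cc1)[C@@H]1CCCN(Cc2ccc(F)c(F)c2)C1`, 4000 nM

Both compounds were tested in a functional assay on A-375 cells (Homo sapiens) for activation, with a stated time of 3 days; a higher number here means that more compound is needed for the effect, a lower number that less compound is needed. Compound 1 holds the lowest of the two numbers; its nearest neighbour is compound 2, with a 3.2-fold higher number from compound 1 to compound 2 (0.51 log units; beyond the scatter). The two structures share every atom and bond, and the step rests on (the fact that one of compounds 1 and 2 is drawn with a defined configuration and the other without, at the place where they differ).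

Compound 3, `O=C(Nc1ccc(-c2ccsc2)cc1)C1CCCN(Cc2ccc(F)c(F)c2)C1`, has not yet been measured in this assay. It differs from compound 1 by thiophen-3-yl in place of 1,3-thiazol-4-yl on an aromatic carbon. Within the data shown here, neither measured step touches this part of the molecule: the only step available concerns the ring carbon configuration, not the five-membered aromatic ring. There is therefore no measured evidence on how this change should move the number, and the expectation leans on compound 1 alone.

Compound 3 is expected to sit close to compound 1, with a step of a 1.2-fold higher number from compound 1 to compound 3 (0.08 log units; within the scatter), which would not go beyond the scatter. In this assay compound 3 is estimated at 1500 nM, within a range from 500 nM to 5000 nM.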

Compound 3, half-maximal effective concentration: 1930 nM
For compound 3 the middle estimate is 1.3-fold (0.11 log units) below the measured one, and the stated range covers the measured number.
By their numbers in this assay, from the lowest: compounds 1 and 3 (each within the scatter of the next); then compound 2.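

In this assay, thiophen-3-yl in place of 1,3-thiazol-4-yl, on an aromatic carbon para to a large group, gives a 1.6-fold higher number from compound 1 to compound 3 (0.19 log units; within the scatter). Among these compounds, this is the first reading at this position, as the earlier step concerned only a stereocentre at a saturated ring carbon, and it shows that compound 1 and compound 3 cannot be told apart here even though the ring with 2 hetero atoms gives way to one with 1 hetero atom, and 2 hydrogen-bond acceptors to 1. The only available observation on these compounds concerns how that stereocentre is drawn, so it has no bearing on this change to the five-membered aromatic ring.

The compounds shown leave open whether this position would tolerate a larger departure from these two rings, such as a phenyl ring, a pyridine ring, a carboxylic acid or an amine in the same place. They also leave open how the S configuration at the saturated ring carbon would read, and whether thiophen-3-yl would behave the same way in a compound with a defined configuration there.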